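Demethylation in Two Chalcone Cores Against Colon Cancer Cells

This account rests on a few compounds, and the source may have more. Where it says the series, first, only, none or still open, it means among the compounds named here.

Compound 1 `COc1ccc(/C=C/C(=O)c2ccccc2-c2ccc(F)cc2)cc1OC` and compound 2 `COc1ccc(/C=C/C(=O)c2ccccc2-c2ccc(F)cc2)cc1O` share a core and differ only at one place: hydrogen in place of methyl on an oxygen on an aromatic ring. In a functional assay on SW480 cells (Homo sapiens) for antiproliferative activity, read by sulforhodamine B assay, with a stated time of 48 h (a higher number here means a weaker inhibitor, a lower number a stronger inhibitor), compound 1 gives 570 nM, while compound 2 gives 57 nM, a step of a 10-fold lower number from compound 1 to compound 2 (1.00 log units; beyond the scatter). Compound 3 `COc1ccc(C(=O)/C=C/c2ccccc2-c2ccc(F)cc2)cc1OC` is built from the same atoms as compound 1, joined differently; the difference between the two cores is not broken down here. In this assay compound 3 gives 8300 nM, the highest of the three numbers. Compound 4 `COc1cc(C(=O)/C=C/c2ccccc2-c2ccc(F)cc2)ccc1O` carries the same change on the core of compound 3: hydrogen in place of methyl on an oxygen on an aromatic ring. Compound 4 has not yet been measured in this assay. Because the change from compound 1 to compound 2 gave a 10-fold lower number from compound 1 to compound 2 (1.00 log units; beyond the scatter), a similar step is expected from compound 3 to compound 4, namely an 8.3-fold lower number from compound 3 to compound 4 (0.92 log units; beyond the scatter), though the core differs. Compound 4 is therefore estimated at 1000 nM, between 300 nM and 4000 nM.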

Compound 4, half-maximal inhibitory concentration: 4200 nM
For compound 4 the middle estimate is 4.2-fold (0.62 log units) below the measured one; the whole stated range lies below it.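

In this assay, methoxy to hydroxy on the core of compound 3 gives a 2.0-fold lower number from compound 3 to compound 4 (0.30 log units; within the scatter), so this pair shows no difference that can be told from repeat measurement. The same change therefore did not carry over in size from the core of compound 1 to the core of compound 3: the same change on two cores in this assay, a 10-fold lower number (1.00 log units; beyond the scatter) from compound 1 to compound 2 and a 2.0-fold lower number (0.30 log units; within the scatter) from compound 3 to compound 4, 5.1-fold (0.70 log units) apart, beyond the scatter of two such steps. This rests on one pair per core, and the methyl leaves a different one of the two oxygens in each pair, so the result does not show whether the core or the oxygen concerned accounts for the gap.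

The compounds shown leave open how each core would respond if the methyl came off the other oxygen. They also leave open what an amine or a longer alkoxy chain would do in place of the hydroxy.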